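This account rests on a few compounds, and the source may have more. Where it says the series, first, only, none or still open, it means among the compounds named here.

Of the compounds shown here, three built on one shared core have been tested in an assay for binding affinity to Apoptosis regulator Bcl-2 (Homo sapiens), read by fluorescence polarization, with stated times of 30 min and 20 min, tested at 100 uM; a higher number here means more inhibition at the concentration tested (going by the name of the read-out), a lower number less inhibition. Compound 1 `COc1ccc(Oc2ccccc2-c2ccsc2S(=O)(=O)N2CCN(C(=S)Nc3ccc([N+](=O)[O-])cc3)CC2)cc1OC` gives 16%, compound 3 `COc1ccc(Oc2ccccc2-c2ccsc2S(=O)(=O)N2CCN(C(=S)Nc3ccc(Cl)cc3)CC2)cc1OC` gives 18%, and compound 2 `O=C(Nc1ccc(F)cc1)N1CCN(S(=O)(=O)c2sccc2-c2ccccc2Oc2ccc(O)c(O)c2)CC1` gives 33%. On these numbers compound 3 stands second highest of the three: its nearest neighbour is compound 1, separated by a difference within the scatter, and its furthest is compound 2, separated by a gap beyond the scatter.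

The next compound, compound 4 `COc1ccc(Oc2ccccc2-c2ccsc2S(=O)(=O)N2CCN(C(=O)Nc3ccc(F)cc3)CC2)cc1OC`, is compound 3 with a group of 10 heavy atoms (7 carbon, 1 nitrogen, 1 oxygen, 1 fluorine; one six-membered aromatic ring of carbon only) in place of a group of 10 heavy atoms (7 carbon, 1 nitrogen, 1 sulfur, 1 chlorine; one six-membered aromatic ring of carbon only), on an amine nitrogen in a ring. Within the data shown here, only one measured step touches that same part of the molecule: the exchange of groups on the aromatic ring that gave a number 2 percentage points higher from compound 1 to compound 3 (within the scatter), a movement within the scatter. Among the measured compounds shown here, no measured pair isolates the exchange of the sulfur-bearing link for the carbamoyl one. Compound 2 also carries a (4-fluorophenyl)carbamoyl group, yet it differs from compound 4 elsewhere as well, so its reading does not settle this change on its own.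

With only a within-scatter step to go on, the step of a number 4 percentage points higher from compound 3 to compound 4 (within the scatter) is expected to stay within the scatter. Compound 4 is therefore estimated at 22%, most likely between 8% and 40%.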

Compound 4, a percentage reported as inhibition, at one concentration (the size of the read-out at that concentration, not a potency): 15%
Compound 4: the middle estimate sits 7 percentage points above what was measured; measured number inside the range.
By their numbers in this assay, from the lowest: compounds 4, 1 and 3 (each within the scatter of the next); then compound 2.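

In this assay, compound 4 shows that a (4-fluorophenyl)carbamoyl group on the amine nitrogen in the ring reads the same, within the scatter, as the two larger groups carrying sulfur (a number 3 percentage points lower from compound 3 to compound 4 (within the scatter); a number 1 percentage points lower from compound 1 to compound 4 (within the scatter)), so neither exchange at this position can be told apart in these readings. Among these compounds, compound 4 also gives the first pair that isolates the group on the oxygen on an aromatic ring, where 3,4-dimethoxyphenyl in place of 3,4-dihydroxyphenyl gives a step beyond the scatter (a number 18 percentage points lower from compound 2 to compound 4 (beyond the scatter)), the only such step among the new ones. No accompanying measurement accounts for that step.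

Going by these compounds, it remains open whether the 3,4-dihydroxyphenyl group would give a similar step with the sulfur-bearing groups on the ring nitrogen, since compound 2 carries it only with the (4-fluorophenyl)carbamoyl group. The compounds shown also leave open how other groups would read on the ring nitrogen, such as a simple acetyl or a longer chain ending in a carboxylic acid, and whether a single hydroxy or an amine on the phenyl ring bound through oxygen would be enough.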